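Working notes: methoxy in place of bromo

A few compounds are considered here, and "the series" means these few. Any claim that something is new, unique, unknown or untested is made for them only; others in the source may bear on it.

Values in an ADME assay on J774.A1 cells (Mus musculus) for cytotoxicity, read by MTT assay, with a stated time of 72 h; a higher number here means that more compound is tolerated, a lower number that less compound is tolerated:
- compound 1 `COC(=O)C1=C(C)N(c2ccc(OC)cc2)C(C)=C(C(=O)OC)C1[C@@H]1O[C@H]2OC(C)(C)O[C@H]2[C@@H]1OCc1ccccc1`: 14.1 ug/mL
- compound 2 `COC(=O)C1=C(C)N(c2ccc(C)cc2)C(C)=C(C(=O)OC)C1[C@@H]1O[C@H]2OC(C)(C)O[C@H]2[C@@H]1OC`: 33.1 ug/mL
- compound 3 `COC(=O)C1=C(C)N(c2ccc(Br)cc2)C(C)=C(C(=O)OC)C1[C@@H]1O[C@H]2OC(C)(C)O[C@H]2[C@@H]1OC`: 48.5 ug/mL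
- compound 4 `COC(=O)C1=C(C)N(c2ccc(OC)cc2)C(C)=C(C(=O)OC)C1[C@@H]1O[C@H]2OC(C)(C)O[C@H]2[C@@H]1OC`: not yet measured

Compound 3 at 48.5 ug/mL lies within the scatter of compound 2 and beyond the scatter of compound 1, with the number for compound 3 the higher of that last pair. Compound 4 differs from compound 3 in one place, methoxy in place of bromo on an aromatic carbon.

For the measured compounds named here, one measured step bears on this change. It is a 1.5-fold higher number from compound 2 to compound 3 (0.17 log units; within the scatter), with bromo in place of methyl on an aromatic carbon, and it lies within the scatter. Going by the values given here, no measured step shows methoxy entering at this place in a single change, so the evidence is thin. Among the compounds with values here, no shift beyond the scatter is expected in this assay because a 1.5-fold higher number from compound 2 to compound 3 (0.17 log units; within the scatter) is the only measured change at this place. The estimated step is a 1.2-fold lower number from compound 3 to compound 4 (0.08 log units; within the scatter), a small one with no firm direction. Compound 4 is expected at 40 ug/mL, with an estimated range of 20 ug/mL to 80 ug/mL.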

Compound 4, half-maximal cytotoxic concentration: 18.6 ug/mL
Estimate against measurement, compound 4: 2.2-fold (0.33 log units) above; measured number below the stated range.
By their numbers in this assay, from the lowest: compounds 1, 4, 2 and 3 (each within the scatter of the next, the first and the last beyond it).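

In this assay, for the compounds shown here, methoxy in place of bromo on the aromatic carbon gives the first single change at this place that lies beyond the scatter (a 2.6-fold lower number from compound 3 to compound 4 (0.42 log units; beyond the scatter)), so the group here can shift the number, which the methyl and bromo pair did not show. Methoxy and methyl remain unresolved, with their step within the scatter (a 1.8-fold lower number from compound 2 to compound 4 (0.25 log units; within the scatter)), so only the bromo and methoxy pair separates at this place. With methoxy held on the aromatic ring, the change at the saturated chain carbon also stays within the scatter (a 1.3-fold higher number from compound 1 to compound 4 (0.12 log units; within the scatter)).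

Nothing given here accounts for the separation between bromo and methoxy. From the compounds shown here alone, whether an amine or a carboxylic acid at this aromatic carbon would extend or reverse the step remains open.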